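The source may hold more compounds than are shown below. What is called first, only, known or untested is meant among the compounds shown, and "the series" means these compounds.

Measured so far in a functional assay on MDA-MB-231 cells (Homo sapiens) for inhibition, read by sulforhodamine B assay, with a stated time of 72 h; on this read-out higher numbers stand for weaker inhibition of growth and lower numbers for stronger inhibition of growth:

Compound 1 `CN1CCN(C(=O)/C=C/c2ccncc2-c2ccc3ccccc3c2)CC1` gives > 10000 nM
Compound 2 `CCOC(=O)/C=C/c1ccncc1-c1ccc2c(cnn2C)c1` gives > 10000 nM
Compound 3 `CCOC(=O)/C=C/c1ccncc1-c1ccc2[nH]ccc2c1` gives > 10000 nM

Compound 3 stands at > 10000 nM in this assay and that is a limit, not a number. The same holds across the series, with the limit of > 10000 nM in this assay, at which 3 of the 3 values shown sit, as the whole picture so far.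

Compound 4 `CNC(=O)/C=C/c1ccncc1-c1ccc2[nH]ccc2c1` carries methylamino in place of ethoxy on a carbonyl carbon, which turns ethoxycarbonyl into methylcarbamoyl; its difference from compound 3 is methylamino in place of ethoxy on a carbonyl carbon and the rest of the structure is unchanged.

Within the data shown here, no measured step covers this change, so the data give no size for it. Among the measured compounds shown here, no shift beyond the usual scatter is expected, in either direction, and the only anchor is compound 3 at > 10000 nM as a limit. The expected step, a step that the limit leaves unreadable from compound 3 to compound 4, is an estimate only. A result reported again as a limit is expected to be the most likely outcome. The estimate for compound 4 is 12000 nM with an expected range from 3000 nM to 30000 nM as the working figure.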

Compound 4, concentration for 50% growth inhibition: > 10000 nM
Compound 4 was reported as a limit; the forecaster's own chance of this, stated with the estimate: 70%; the middle value is on the limit's open side.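

In this assay no step can be read between compound 3 and compound 4; both values are limits. Left open is whether methylamino in place of ethoxy on a carbonyl carbon changes growth inhibition at all, and whether any compound of this series gives a measurable value.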